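Trimming the Amine Side Chain of Compound 1

The source may hold more compounds than are shown below. What is called first, only, known or untested is meant among the compounds shown, and "the series" means these compounds.

Compound 1 `CC/N=C(/NC#N)NCCCCn1nc(-c2ccccc2)ccc1=O` stands highest of the three compounds measured in a functional assay on the whole organism with Rattus norvegicus as the target, at a dose of 100 mg/kg (a lower number here means less inhibition, a higher number more inhibition at the dose given (going by the name of the read-out)), where compound 1 gives 58.8%. Compound 2 `CC/N=C(/NC#N)NCCCCn1nc(-c2ccccc2)cc(C)c1=O` gives 42.5%, and compound 3 `CC/N=C(/NC#N)NCCCCn1nc(C)ccc1=O` gives 13.5%. Both measured steps alter the aromatic part of the shared core: a number 16.3 percentage points lower from compound 1 to compound 2 (beyond the scatter), and a number 45.3 percentage points lower from compound 1 to compound 3 (beyond the scatter). Every change so far has lowered the read-out, the larger change producing the larger fall, though two steps cannot establish a rule.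

Compound 4 `N#CNC(=N)NCCCCn1nc(-c2ccccc2)ccc1=O` differs from compound 1 at a different place: a group of 5 heavy atoms (2 carbon, 3 nitrogen; no ring) in place of a group of 7 heavy atoms (4 carbon, 3 nitrogen; no ring), on an amine nitrogen. Neither measured step touches the amine nitrogen, so no comparison of the same kind exists. The measured steps show only that this series is sensitive to structural change, with decreases of modest to large size, and that the side chain on the amine nitrogen has so far been kept the same. For the measured compounds named here, with no direct precedent, one expects compound 4 to move in the same downward direction as the measured steps, but with a step of modest size, since the core that carries the phenyl group is kept intact. Compound 4 is expected to give 48%, with a range from 25% to 68%. That estimate corresponds to an expected step of a number 10.8 percentage points lower from compound 1 to compound 4 (beyond the scatter).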

Compound 4, a percentage reported as inhibition, in the whole organism at one dose (the size of the read-out at that dose, not a potency): 61.2%
For compound 4 the middle estimate is 13.2 percentage points below the measured one; the range from low to high includes it.
By their numbers in this assay, from the lowest: compound 3; then compound 2; then compounds 1 and 4 (each within the scatter of the next).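

Replacing the group of 7 heavy atoms on the amine nitrogen with the group of 5 heavy atoms gives a number 2.4 percentage points higher from compound 1 to compound 4 (within the scatter) in this assay. Unlike the two changes to the aromatic part of the shared core, this change produces no step beyond the scatter, so the sensitivity seen in the earlier steps does not extend to this one change on the amine nitrogen, even though the count of hydrogen-bond donors goes from 1 to 2. Nothing available here accounts for this difference between the two parts of the molecule.

The compounds shown leave open whether the amine nitrogen would accept other groups in the same way, such as a longer chain of butyl or a phenyl ring, since a single change cannot mark the limits of what this place allows. They also leave open whether compound 1 and compound 4 would remain within the scatter of each other at other doses, and whether the methyl group that accompanies the lower number in compound 2 would have the same effect in the setting of compound 4.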